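From 4-Fluorobenzyl to 2-Methoxyphenoxy: an Acidity Estimate

The source may report more compounds than this note shows. Statements on the series, on what has been measured and on what is new or still open speak of the compounds shown alone.

Compound 1, `COc1ccc(F)cc1CNCCCNc1ccnc2cc(Oc3ccc(F)cc3)ccc12`, gives 9.28 in a physicochemical assay for acid dissociation.
Compound 2, `COc1ccc(F)cc1CNCCCNc1ccnc2cc(Cc3ccc(F)cc3)ccc12`, gives 9.47 in this assay.

Among the compounds with values here, only two compounds have been measured, and compound 2 is the one reached by the single step of a number 0.19 log units higher from compound 1 to compound 2 (within the scatter), a gap that stays within the usual scatter. The two numbers therefore lie within the scatter of each other.

Compound 3, `COc1ccc(F)cc1CNCCCNc1ccnc2cc(Oc3ccccc3OC)ccc12`, has not yet been measured. Its difference from compound 2 is 2-methoxyphenoxy in place of 4-fluorobenzyl on an aromatic carbon. Within the data shown here, this is close to a reversal of the one step seen so far: the earlier exchange of 4-fluorophenoxy for 4-fluorobenzyl gave a number 0.19 log units higher from compound 1 to compound 2 (within the scatter), no real movement, and the new change puts a phenoxy group back in the same place, now carrying a methoxy rather than a fluorine. Among the measured compounds shown here, with only that one flat step to lean on, no shift beyond the scatter is expected in this assay.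

Compound 3 is estimated at 9.35, with a range from 9 to 9.7. This means the expected step is a number 0.12 log units lower from compound 2 to compound 3 (within the scatter), a change that should not stand out from repeat measurements.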

Compound 3, acid dissociation constant: 9.28
Compound 3: the middle estimate sits 0.07 log units above what was measured, within the range that was stated.
By their numbers in this assay, from the lowest: compounds 1, 3 and 2 (each within the scatter of the next).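

In this assay the exchange of 4-fluorobenzyl for 2-methoxyphenoxy on this aromatic carbon gives a number 0.19 log units lower from compound 2 to compound 3 (within the scatter) and so adds a second group of a different shape and make-up at this position without any change that stands out from repeat measurements. The comparison between the two phenoxy groups is new as well: with the oxygen link kept and 2-methoxyphenyl in place of 4-fluorophenyl, the result is no change at the digits printed from compound 1 to compound 3 (within the scatter) in the same read-out, so moving from a fluorine to a methoxy on the outer ring, at another ring position, leaves no detectable mark here. All three groups tried at this place therefore read alike within the scatter, and nothing measured here speaks to the reason for that.

As far as these compounds go, all three groups are uncharged and carry a six-membered aromatic ring of carbon only, so it remains open whether an amine, a carboxylic acid or a plain longer alkyl chain at this carbon would also leave the number in place. The rest of the molecule is identical across compounds 1, 2 and 3, which leaves the effect of any change elsewhere on the shared core or its side chain unknown.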